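A few compounds are considered here, and "the series" means these few. Any claim that something is new, unique, unknown or untested is made for them only; others in the source may bear on it.

In a functional assay on LNCaP cells (Homo sapiens) for cytotoxicity (on this read-out lower numbers stand for stronger inhibition and higher numbers for weaker inhibition), two compounds sharing one core have been measured so far. Compound 1 `CNC(=O)Nc1ccc(-c2nc(N3CC4CCC(C3)O4)c3cnn(CCN(C)C)c3n2)cc1`, with a 2-(dimethylamino)ethyl on an aromatic nitrogen, gives 400 nM. Compound 2 `CNC(=O)Nc1ccc(-c2nc(N3CC4CCC(C3)O4)c3cnn([C@H]4CC[C@H](OC)CC4)c3n2)cc1`, with a 4-methoxycyclohexyl in that place, gives 2 nM, the lower of the two numbers. Compound 3 `CNC(=O)Nc1ccc(-c2nc(N3CC4CCC(C3)O4)c3cnn(C4CCC(OC)(OC)CC4)c3n2)cc1` has not yet been measured and changes the same place: a group of 10 heavy atoms (8 carbon, 2 oxygen; one six-membered non-aromatic ring of carbon only) in place of a group of 8 heavy atoms (7 carbon, 1 oxygen; one six-membered non-aromatic ring of carbon only), on an aromatic nitrogen. Within the data shown here, only one measured step bears on this change, a 200-fold lower number from compound 1 to compound 2 (2.30 log units; beyond the scatter). That large step shows that the read-out can move strongly with the group on this nitrogen. However, it exchanged the 2-(dimethylamino)ethyl for a group with a ring, whereas the entering group keeps a six-membered non-aromatic ring of carbon only. Among the measured compounds shown here, no measured compound shows what the second oxygen does, so the direction remains uncertain. A modest rise in this assay is expected, much smaller than the measured step, and the expected step is a 2.5-fold higher number from compound 2 to compound 3 (0.40 log units; beyond the scatter). For compound 3 the estimated value is 5 nM, with an expected range from 1 nM to 30 nM.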

Compound 3, half-maximal inhibitory concentration: 2 nM
Compound 3: middle estimate off by 2.5-fold (0.40 log units), on the high side; measured number inside the range.
By their numbers in this assay, from the lowest: compounds 2 and 3 (each within the scatter of the next); then compound 1.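

Exchanging the 4-methoxycyclohexyl for the group of 10 heavy atoms, with 2 hydrogen-bond acceptors in place of 1, gives in this assay no change at the digits printed from compound 2 to compound 3 (within the scatter) and thus no readable effect at this position. On this aromatic nitrogen, the six-membered carbon ring therefore takes the larger oxygen-bearing group without a shift beyond the scatter, even though the entering group has no defined stereocentres and the group it replaces has 2. The large gain seen earlier is also not unique to 4-methoxycyclohexyl, since a 200-fold lower number from compound 1 to compound 3 (2.30 log units; beyond the scatter) is seen in this assay when the second ring-bearing group replaces the 2-(dimethylamino)ethyl. No measurement on hand gives a reason for either result.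

The compounds shown do not separate the effect of the carbon ring from that of removing the dimethylamino group, which a plain cyclohexyl or an open 2-methoxyethyl chain on the same nitrogen would address. They also leave open whether this tolerance extends to an amine or a carboxylic acid on the ring.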